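This account rests on a few compounds, and the source may have more. Where it says the series, first, only, none or still open, it means among the compounds named here.

Compound 2 `CC(C)Cn1nnc2c(Br)cccc21` gives 4 mL/min/g in an ADME assay on microsomes from liver (Rattus norvegicus, strain Wistar) for metabolic stability, tested at 2.5 uM (on this read-out higher numbers stand for fast clearance and lower numbers for slow clearance), the lowest of the two numbers seen; compound 1 `Brc1cccc2c1nnn2CC1CCCC1` gives 14.6 mL/min/g in this assay. Going by the values given here, the one step seen, a 3.7-fold lower number from compound 1 to compound 2 (0.56 log units; beyond the scatter), was modest. Compound 3 `CCCCn1nnc2c(Br)cccc21` differs from compound 2 by propyl in place of isopropyl on a saturated chain carbon bound to an aromatic nitrogen. That step, a ring to a branched chain, bears only loosely on a branched chain becoming a straight one of the same size, so compound 3 is expected to show no step beyond the scatter, a 1.3-fold higher number from compound 2 to compound 3 (0.10 log units; within the scatter). Compound 3 is estimated at 5 mL/min/g, within 2.5 mL/min/g to 10 mL/min/g.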

Compound 3, intrinsic clearance in a liver preparation (reported as CLH), per the amount of preparation that the assay uses: 4.4 mL/min/g
Compound 3: middle estimate off by 1.1-fold (0.06 log units), on the high side; the measured number falls inside the stated range.
By their numbers in this assay, from the lowest: compounds 2 and 3 (each within the scatter of the next); then compound 1.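

In this assay, a branched chain and a straight one at this place cannot be told apart, with a 1.1-fold higher number from compound 2 to compound 3 (0.04 log units; within the scatter). The gap to the ring persists with the straight chain, with a 3.3-fold lower number from compound 1 to compound 3 (0.52 log units; beyond the scatter), so cyclopentyl stands apart from both open chains, which compound 2 alone could not show. Nothing available here accounts for this. From the compounds shown here alone, whether a longer chain, or a chain carrying an amine or a carboxylic acid, would keep the number this low remains open. So does whether a smaller ring such as cyclopropyl would behave like cyclopentyl.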